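The source may report more compounds than this note shows. Statements on the series, on what has been measured and on what is new or still open speak of the compounds shown alone.

Of the compounds shown here, three from one study have been measured in a functional assay on HCT-8 cells (Homo sapiens) for antiproliferative activity, read by MTT assay, with a stated time of 48 h; a lower number here means a stronger inhibitor, a higher number a weaker inhibitor. Compound 1, `COc1ccc(C(=O)c2ccc3c(c2)C=CC(C)(C)O3)c(NC(=O)CN)c1`, gives 490 nM in this assay. Compound 2, `COc1ccc(C(=O)c2ccc3c(c2)C=CC(C)(C)O3)c(NC(=O)CN(C)C)c1`, gives 2420 nM in this assay. Compound 3, `COc1ccc(C(=O)c2cc(OC)c(OC)c(OC)c2)c(NC(=O)CN(C)C)c1`, gives 790 nM in this assay. Compound 4, `COc1ccc(C(=O)c2cc(OC)c(OC)c(OC)c2)c(NC(=O)CN)c1`, has not yet been measured in this assay.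

Compound 2 and compound 1 share one core and differ in a single place, (amino in place of dimethylamino on a saturated chain carbon bound to a carbonyl carbon). This change made a 4.9-fold lower number from compound 2 to compound 1 (0.69 log units; beyond the scatter). Compound 3 and compound 4 differ by the same change on a different core, (amino in place of dimethylamino on a saturated chain carbon bound to a carbonyl carbon), at a place described in the same words. The difference between the two cores is not broken down here. The number for compound 3 lies within the scatter of the number for compound 1 and beyond the scatter of the number for compound 2.

Within the data shown here, only one pair with this change has been measured, so whether it carries over to the core of compound 3 is not known. Among the measured compounds shown here, the step is expected to be a little smaller than the measured one because the only measured instance of the change is a 4.9-fold lower number from compound 2 to compound 1 (0.69 log units; beyond the scatter), seen on another core. In this assay the expected step is a 3.6-fold lower number from compound 3 to compound 4 (0.56 log units; beyond the scatter). Compound 4 is therefore estimated at 220 nM, with the likely range from 90 nM to 550 nM.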

Compound 4, half-maximal inhibitory concentration: 330 nM
Beside the measured number, compound 4's estimate is 1.5-fold (0.18 log units) below it, within the range that was stated.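

In this assay, putting amino in place of dimethylamino on a saturated chain carbon bound to a carbonyl carbon again lowers the number, giving a 2.4-fold lower number from compound 3 to compound 4 (0.38 log units; beyond the scatter), so the direction of the change seen on the first core also holds on the second. Set side by side, the sizes of the two steps cannot be told apart, even though the printed figures are not identical: the same change on two cores in this assay, a 4.9-fold lower number (0.69 log units; beyond the scatter) from compound 2 to compound 1 and a 2.4-fold lower number (0.38 log units; beyond the scatter) from compound 3 to compound 4, 2.1-fold (0.31 log units) apart, within the scatter of two such steps. This supports treating the change as transferable across these two cores, but it rests on a single pair for each core, so it does not show that the step would hold on any further core, and it does not explain why the number falls.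

The compounds shown carry only amino and dimethylamino at this place, so it remains open how methylamino, a ring amine such as pyrrolidine or a longer chain carrying the amine would compare. All of these numbers also come from one kind of cell in one assay, so whether the same step appears in other cell lines remains an open question as well.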